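Lipophilicity after a change on the amide-type nitrogen

A few compounds are considered here, and "the series" means these few. Any claim that something is new, unique, unknown or untested is made for them only; others in the source may bear on it.

Measured in a physicochemical assay for lipophilicity, at pH 7.4 (on this read-out higher numbers stand for higher lipophilicity and lower numbers for lower lipophilicity), so far
- compound 1 `O=C(Nc1cnc2[nH]ncc2c1)[C@H]1CCCN1C(=O)C1(c2cccc(Cl)c2)CCCC1` gives 4.9 on this read-out
- compound 2 `O=C(Nc1ccc2[nH]ncc2n1)[C@H]1CCCN1C(=O)C1(c2ccc(Cl)cc2)CC(F)(F)C1` gives 4.7 on this read-out

For the measured compounds named here, the values of compound 1 and compound 2 lie within the usual scatter of each other, so compound 1 stands level with the only other measured compound. Compound 3 `O=C(Nc1ccc(O)cc1)[C@H]1CCCN1C(=O)C1(c2cccc(Cl)c2)CCCC1` keeps the rest of compound 1 but carries 4-hydroxyphenyl on the amide-type nitrogen (a group of 7 heavy atoms (6 carbon, 1 oxygen; one six-membered aromatic ring of carbon only) in place of a group of 9 heavy atoms (6 carbon, 3 nitrogen; one five-membered aromatic ring with 2 hetero atoms, one six-membered aromatic ring with 1 hetero atom), on an amide-type nitrogen). Going by the values given here, no measured pair differs in one place only, so the data offer no direct guide. In this assay no change beyond the scatter is expected, and the estimated shift is small (a number 0.10 log units lower from compound 1 to compound 3 (within the scatter)). Compound 3 is estimated at 4.8 (expected range 4.3 to 5.3) in the coming measurement.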

Compound 3, distribution coefficient: 5.5
Estimate against measurement, compound 3: 0.70 log units below; the measured number lies above the stated range.
By their numbers in this assay, from the lowest: compounds 2 and 1 (each within the scatter of the next); then compound 3.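

For the compounds shown here, the first single-place step at this position shows that it can move this assay beyond the scatter: 4-hydroxyphenyl on the amide-type nitrogen, in place of the group with two aromatic rings, gives a number 0.60 log units higher from compound 1 to compound 3 (beyond the scatter). Nothing available bears on why the number rose.

With one replacement at this position, the compounds shown leave open whether the rise goes with the hydroxyl or with the loss of the ring nitrogens. They also leave open how plain phenyl, or a phenyl carrying a carboxylic acid or an amine, would read in this assay.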